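A Methoxy Group Enters the Hydroxyphenyl Arm of Compound 2

The source may hold more compounds than are shown below. What is called first, only, known or untested is meant among the compounds shown, and "the series" means these compounds.

Three analogues on one shared core have been tested in a functional assay on MKN-45 cells (Homo sapiens) for cytotoxicity, read by MTT assay, with a stated time of 72 h; on this read-out higher numbers stand for weaker inhibition and lower numbers for stronger inhibition. Compound 1 `CN(C)CCn1cnnc1-c1cc(Oc2ccc(NC(=O)N/N=C/c3cccc(O)c3)cc2F)ccn1` gives 1370 nM. Compound 2 `CN(C)CCn1cnnc1-c1cc(Oc2ccc(NC(=O)N/N=C/c3ccc(O)cc3)cc2F)ccn1` gives 820 nM, the lowest of the three numbers, and compound 3 `COc1ccc(/C=N/NC(=O)Nc2ccc(Oc3ccnc(-c4nncn4CCN(C)C)c3)c(F)c2)cc1O` gives 2510 nM. The measured moves are small: a 1.7-fold lower number from compound 1 to compound 2 (0.22 log units; within the scatter) and a 1.8-fold higher number from compound 1 to compound 3 (0.26 log units; within the scatter), while a 3.1-fold higher number from compound 2 to compound 3 (0.49 log units; beyond the scatter).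

Compound 4 `COc1cc(/C=N/NC(=O)Nc2ccc(Oc3ccnc(-c4nncn4CCN(C)C)c3)c(F)c2)ccc1O` has not yet been measured in this assay. It differs from compound 2 in one place: methoxy in place of hydrogen on an aromatic carbon. Going by the values given here, two measured steps bear on this. The step from compound 1 to compound 3 is the same change, methoxy in place of hydrogen on an aromatic carbon ortho to a hydroxy group, and it moved the number only within the scatter: a 1.8-fold higher number from compound 1 to compound 3 (0.26 log units; within the scatter). The step from compound 2 to compound 3 also brings in a methoxy, but as 3-hydroxy-4-methoxyphenyl in place of 4-hydroxyphenyl, and it reached beyond the scatter: a 3.1-fold higher number from compound 2 to compound 3 (0.49 log units; beyond the scatter). Because a 1.8-fold higher number from compound 1 to compound 3 (0.26 log units; within the scatter) is the same change on an arm that keeps its hydroxy, and compound 4 likewise keeps the 4-hydroxyphenyl of compound 2 and gains only the methoxy, a modestly higher number is expected, near the edge of the scatter. Compound 4 is therefore estimated at 1500 nM, with a range from 700 nM to 3500 nM. This expected move corresponds to a 1.8-fold higher number from compound 2 to compound 4 (0.26 log units; within the scatter).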

Compound 4, half-maximal inhibitory concentration: 3780 nM
Compound 4: the middle estimate sits 2.5-fold (0.40 log units) below what was measured, and the stated range ends below it.
By their numbers in this assay, from the lowest: compounds 2, 1, 3 and 4 (each within the scatter of the next, the first and the last beyond it).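

In this assay, going by these compounds alone, the change to 4-hydroxy-3-methoxyphenyl (a 4.6-fold higher number from compound 2 to compound 4 (0.66 log units; beyond the scatter)) is the first step of methoxy in place of hydrogen here that goes beyond the scatter, so on this arm a methoxy ortho to a hydroxy group is not a neutral addition. Set beside the same change on the arm of compound 1, however, this larger step does not show that the two arms respond differently: the same change on two cores in this assay, a 1.8-fold higher number (0.26 log units; within the scatter) from compound 1 to compound 3 and a 4.6-fold higher number (0.66 log units; beyond the scatter) from compound 2 to compound 4, 2.5-fold (0.40 log units) apart, within the scatter of two such steps. Exchanging the places of hydroxy and methoxy gives no separation (a 1.5-fold higher number from compound 3 to compound 4 (0.18 log units; within the scatter)), so compound 3 and compound 4 cannot be told apart, whereas the step from the arm with hydroxy alone (a 2.8-fold higher number from compound 1 to compound 4 (0.44 log units; beyond the scatter)) passes the scatter, and both methoxy arms therefore sit on the weaker side of the series.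

The compounds shown leave open whether a fluorine, a methyl, an ethoxy or an amine on this same aromatic carbon would give a step of similar size. They also leave open whether the step follows the methoxy in particular or any group at this position, as methoxy is the only group shown there.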